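A few compounds are considered here, and "the series" means these few. Any claim that something is new, unique, unknown or untested is made for them only; others in the source may bear on it.

Measured in a functional assay on MCF7 cells (Homo sapiens) for cytotoxicity, read by MTT assay, with a stated time of 72 h; a lower number here means a stronger inhibitor, a higher number a weaker inhibitor:
- compound 1 `COc1ncc(-c2ccc3nc(NC(=O)NCC(=O)N4CCCCC4)nn3c2)cc1NS(=O)(=O)c1ccc(F)cc1`: 570 nM
- compound 2 `COc1ncc(-c2ccc3nc(NC(=O)NCCN4CCCC4)nn3c2)cc1NS(=O)(=O)c1ccc(F)cc1`: 380 nM
- compound 3 `COc1ncc(-c2ccc3nc(NC(=O)NCCN4CCCCC4)nn3c2)cc1NS(=O)(=O)c1ccc(F)cc1`: 200 nM

In this assay, compound 3 is separated from its nearest neighbour by a 1.9-fold lower number from compound 2 to compound 3 (0.28 log units; within the scatter). It is separated from the remaining compound by a 2.9-fold lower number from compound 1 to compound 3 (0.45 log units; beyond the scatter).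

Compound 4 `COc1ncc(-c2ccc3nc(NC(=O)NCCN(C)C)nn3c2)cc1NS(=O)(=O)c1ccc(F)cc1` carries dimethylamino in place of piperidin-1-yl on a saturated chain carbon, two bonds along the chain from an amide-type nitrogen.

Going by the values given here, only one measured step changes the group at this same place, and that is a 1.9-fold lower number from compound 2 to compound 3 (0.28 log units; within the scatter). The other two steps, a 1.5-fold lower number from compound 1 to compound 2 (0.18 log units; within the scatter) and a 2.9-fold lower number from compound 1 to compound 3 (0.45 log units; beyond the scatter), replace a carbonyl-bearing group and so bear on the change only indirectly. Among the compounds with values here, no measured compound carries an open-chain amine here, so the guide is thin. With only compound 2 to go on, at 380 nM, a modest move towards a higher number seems more likely than a move towards a lower one, and it may not clear the scatter. The expected step is a 1.8-fold higher number from compound 3 to compound 4 (0.24 log units; within the scatter). In this assay, the estimated value for compound 4 is 350 nM, with an expected range from 130 nM to 900 nM.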

Compound 4, half-maximal inhibitory concentration: 560 nM
Estimate against measurement, compound 4: 1.6-fold (0.20 log units) below; low and high end bracket the measured number.
By their numbers in this assay, from the lowest: compounds 3, 2, 4 and 1 (each within the scatter of the next, the first and the last beyond it).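

Going by these compounds alone, replacing piperidin-1-yl with dimethylamino gives the first step among the amines at this place that clears the scatter in this assay, with a 2.8-fold higher number from compound 3 to compound 4 (0.45 log units; beyond the scatter), whereas the earlier pyrrolidin-1-yl to piperidin-1-yl step did not. The pyrrolidin-1-yl compound does not separate from the open-chain amine, with a 1.5-fold higher number from compound 2 to compound 4 (0.17 log units; within the scatter), and the dimethylamino compound also stays within the scatter of the compound carrying (piperidin-1-yl)carbonyl on the chain, with a 1.0-fold lower number from compound 1 to compound 4 (0.01 log units; within the scatter), so among the amines only the piperidin-1-yl and dimethylamino ends of this small set are resolved. No supporting evidence is available to explain these differences.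

The compounds shown leave open whether the ring of piperidin-1-yl matters in itself or whether its extra carbon atoms alone account for the step, a question that an open-chain diethylamino group would help to address. They also do not show how a morpholin-4-yl or 4-methylpiperazin-1-yl group, or a longer chain leading to the amine, would read in this assay.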